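A few compounds are considered here, and "the series" means these few. Any claim that something is new, unique, unknown or untested is made for them only; others in the source may bear on it.

Of the compounds shown here, three have been measured in an assay for inhibition of Indoleamine 2,3-dioxygenase 1 (Homo sapiens), with stated times of 10 min and 60 min; on this read-out lower numbers stand for stronger inhibition and higher numbers for weaker inhibition. Compound 1 `FC(F)(F)c1cc(NC[C@H]2CCCN2)c2cn[nH]c2c1` gives 9580 nM. Compound 2 `O=C1NC(=O)c2c(NCc3ccccc3[N+](=O)[O-])cccc21` reaches only a limit of the assay, > 100000 nM. Compound 3 `OC1CCCC(Nc2cccc(CNc3cc(C(F)(F)F)cc4[nH]ncc34)c2)C1` likewise sits at a limit, > 100000 nM. Among the measured compounds shown here, compound 1 therefore holds the only number in this assay, while the limit of > 100000 nM in this assay, at which 2 of the 3 values shown sit, describes where the other two results rest, so no ordering between compound 1 and the others can be drawn beyond the fact that compound 1 alone returns a number.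

Compound 4 `FC(F)(F)c1cc(NC[C@@H]2CCCCN2)c2cn[nH]c2c1` has not been measured. It differs from compound 1 by piperidin-2-yl in place of pyrrolidin-2-yl on a saturated chain carbon bound to a nitrogen on an aromatic ring, the same difference read one bond further out being (pyrrolidin-2-yl)methyl to (piperidin-2-yl)methyl. For the measured compounds named here, no measured pair among the three compounds shows a step of this kind, so there is no comparison to anchor the expectation, and the change itself is small. The expected step is a 1.0-fold higher number from compound 1 to compound 4 (0.02 log units; within the scatter), one that stays within the usual scatter rather than a shift in either direction. Compound 4 is expected to give 10000 nM in this assay, within the range 3000 nM to 40000 nM.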

Compound 4, half-maximal inhibitory concentration: 18700 nM
Compound 4: middle estimate off by 1.9-fold (0.27 log units), on the low side; low and high end bracket the measured number.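

In this assay, piperidin-2-yl in place of pyrrolidin-2-yl on a saturated chain carbon bound to a nitrogen on an aromatic ring gives a 2.0-fold higher number from compound 1 to compound 4 (0.29 log units; within the scatter), so the two rings cannot be told apart at this place. This is the first pair shown that differs in one place, and it indicates that the read-out at this position holds when the ring gains a carbon, with the ring nitrogen and the defined stereocentre still present. Compound 4 also joins compound 1 in returning a number rather than a limit, and the other results remain limits and not numbers: the limit of > 100000 nM in this assay, at which 2 of the 4 values shown sit.

From the compounds shown here alone, a single pair cannot show how far this position tolerates change, so it stays open whether a smaller ring such as azetidin-2-yl, or an open-chain group such as an aminomethyl chain, would give a number in this assay. Also open, going by these compounds, is what the opposite configuration at the stereocentre of either ring would give, and whether a ring without a nitrogen, such as cyclohexyl, would read the same.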